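The compounds below may be only part of what the source reports. "The series", "measured", "known", "first", "only" and "open" are said of these compounds alone.

Measured so far in an assay for inhibition of Amine oxidase [flavin-containing] B (Bos taurus), read by fluorescence, with a stated time of 60 min; on this read-out higher numbers stand for weaker inhibition and lower numbers for stronger inhibition:
compound 1 `Cc1ccc(C(=O)NNC(=O)Cn2c(=O)c(Cc3ccccc3)nc3ccccc32)cc1` — 680000 nM
compound 2 `COc1ccc(/C=N/NC(=O)Cn2c(=O)c(Cc3ccccc3)nc3ccccc32)cc1` — 82000 nM
compound 3 `O=C(Cn1c(=O)c(Cc2ccccc2)nc2ccccc21)N/N=C/c1ccc([N+](=O)[O-])cc1` — 84000 nM

Compound 3 stands second highest of the three numbers in this assay. Its nearest neighbour is compound 2, whose value lies within the scatter of that of compound 3, so no order between the two can be read; the furthest is compound 1, whose number is far higher than that of compound 3.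

Compound 4 `C/C(=N\NC(=O)Cn1c(=O)c(Cc2ccccc2)nc2ccccc21)c1ccc(O)cc1` carries a group of 10 heavy atoms (8 carbon, 1 nitrogen, 1 oxygen; one six-membered aromatic ring of carbon only) in place of a group of 11 heavy atoms (7 carbon, 2 nitrogen, 2 oxygen; one six-membered aromatic ring of carbon only), on an amide-type nitrogen. Going by the values given here, three measured steps bear on this change. The two steps that leave compound 1 gave an 8.3-fold lower number from compound 1 to compound 2 (0.92 log units; beyond the scatter) and an 8.1-fold lower number from compound 1 to compound 3 (0.91 log units; beyond the scatter), both beyond the scatter. The exchange of nitro for methoxy on the aromatic carbon gave a 1.0-fold higher number from compound 2 to compound 3 (0.01 log units; within the scatter), within the scatter. Among the compounds with values here, compound 4 keeps the kind of linkage shared by compound 2 and compound 3, and differs from compound 3 in the ring substituent and in the chain, so the small substituent step is the closer guide; the chain difference has no measured counterpart here. No step beyond the scatter is therefore expected in this assay in either direction. Compound 4 is expected to give about 75000 nM, with a range from 25000 nM to 220000 nM. The expected step is a 1.1-fold lower number from compound 3 to compound 4 (0.05 log units; within the scatter).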

Compound 4, half-maximal inhibitory concentration: 980000 nM
For compound 4 the middle estimate is 13-fold (1.12 log units) below the measured one; the whole stated range lies below it.
By their numbers in this assay, from the lowest: compounds 2 and 3 (each within the scatter of the next); then compounds 1 and 4 (each within the scatter of the next).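

In this assay, the group on the amide-type nitrogen can shift the number well beyond the scatter even when the linkage kind shared by compound 2 and compound 3 is kept: the new group gives a large rise on both comparisons (a 12-fold higher number from compound 3 to compound 4 (1.07 log units; beyond the scatter)) (a 12-fold higher number from compound 2 to compound 4 (1.08 log units; beyond the scatter)), whereas the exchange of nitro for methoxy had left the number within the scatter. Keeping that linkage is therefore no guarantee of the stronger inhibition seen with compound 2 and compound 3, as compound 4 cannot be told apart from compound 1, which has a different linkage (a 1.4-fold higher number from compound 1 to compound 4 (0.16 log units; within the scatter)). No measurement at hand accounts for the loss seen with the entering group, which, unlike the group that leaves, counts a hydrogen-bond donor.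

Compound 4 brings in a methyl group on the linkage and a hydroxyl group on the aromatic ring together, so the compounds shown leave open which of the two carries the step. Also open, as far as these compounds go, is how the number would respond to an amine or a carboxylic acid in the place of that hydroxyl group, with the methyl group absent.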